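The compounds below may be only part of what the source reports. "The series", "measured", "known", "first", "only" and "open" are said of these compounds alone.

Compound 1 `CCC(=O)N1CC2CC(C1)N2`: 5900 nM
Compound 2 `O=C(C1CCC1)N1CC2CC(C1)N2`: 11000 nM
Compound 3 `O=C([C@H]1C[C@@H]1F)N1CC2CC(C1)N2`: 2800 nM

Three amides on a shared core have been tested in an assay on SH-EP1 cells for agonist activity at Neuronal acetylcholine receptor; alpha4/beta2 (Homo sapiens), read by FLIPR and calcium flux; on this read-out lower numbers stand for an effect already at smaller amounts and higher numbers for an effect only at larger amounts of compound. Among them compound 3 stands lowest: the step of a 2.1-fold lower number from compound 1 to compound 3 (0.32 log units; beyond the scatter) and the step of a 3.9-fold lower number from compound 2 to compound 3 (0.59 log units; beyond the scatter) both lie beyond the scatter, while the step of a 1.9-fold higher number from compound 1 to compound 2 (0.27 log units; within the scatter) does not. Compound 4 `C[C@H]1C[C@@H]1C(=O)N1CC2CC(C1)N2` is the next member. The change from compound 3 to compound 4 is methyl in place of fluoro on a saturated ring carbon. Within the data shown here, no measured pair varies the substituent on the three-membered ring itself; the two steps that bear on it are those that exchanged the whole acyl group, and both moved the number only modestly. On that basis a small shift, if any, is expected, most likely back toward the numbers of compound 1 and compound 2. Compound 4 is therefore expected to give about 4000 nM in this assay, in a range from 1500 nM to 11000 nM. This estimate amounts to an expected step of a 1.4-fold higher number from compound 3 to compound 4 (0.15 log units; within the scatter), which would fall within the scatter.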

Compound 4, half-maximal effective concentration: 14000 nM
Compound 4: middle estimate off by 3.5-fold (0.54 log units), on the low side; the measured number lies above the stated range.
By their numbers in this assay, from the lowest: compound 3; then compounds 1, 2 and 4 (each within the scatter of the next, the first and the last beyond it).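

On this saturated ring carbon of the three-membered ring, fluoro and methyl are not interchangeable, although each is a single heavy atom with no hydrogen-bond donors or acceptors: a 5.0-fold higher number from compound 3 to compound 4 (0.70 log units; beyond the scatter) is the largest step among these amides. With methyl, the acyl group no longer stands apart from cyclobutyl, as a 1.3-fold higher number from compound 2 to compound 4 (0.10 log units; within the scatter) shows, and a 2.4-fold higher number from compound 1 to compound 4 (0.38 log units; beyond the scatter) places it beyond the scatter from ethyl in the unfavourable direction, so among these compounds the lowest number goes with 2-fluorocyclopropyl and not with the three-membered ring alone. Nothing presented here explains the difference between fluoro and methyl.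

From the compounds shown here alone, whether plain cyclopropyl, with hydrogen on this carbon, would stand nearer to compound 3 or to compound 4 remains open. So does the place of a hydroxyl or trifluoromethyl group here, and of the other stereoisomers of both acyl groups.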